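Lengthening the fatty chain of a trimethoxyanilide

This account rests on a few compounds, and the source may have more. Where it says the series, first, only, none or still open, it means among the compounds named here.

In an assay on microsomes from intestine for inhibition of acyl-CoA:cholesterol acyltransferase (Oryctolagus cuniculus) (a lower number here means a stronger inhibitor, a higher number a weaker inhibitor), compound 1 `CCCCCCCCCCCCCC(=O)Nc1c(OC)cc(OC)cc1OC` gives 190 nM. Among the compounds with values here, compound 2 `CCCCCCCCCCCCCCCC(=O)Nc1c(OC)cc(OC)cc1OC` gives 54 nM in this assay and so stands at the lowest number of the two measured so far, the only other measured compound, compound 1, lying at a higher number. Within the data shown here, the single step measured, a 3.5-fold lower number from compound 1 to compound 2 (0.55 log units; beyond the scatter), came with ethyl in place of hydrogen on a saturated chain carbon, ten or more bonds along the chain from a carbonyl carbon. Compound 3 `CCCCCCCCCCCCCCCCCC(=O)Nc1c(OC)cc(OC)cc1OC` has not yet been measured; it differs from compound 2 by ethyl in place of hydrogen on a saturated chain carbon, ten or more bonds along the chain from a carbonyl carbon, the same kind of change made once more. Because the earlier step of a 3.5-fold lower number from compound 1 to compound 2 (0.55 log units; beyond the scatter) lowered the number beyond the scatter, a further decrease is expected, although a second lengthening need not repeat the first in full. Compound 3 is therefore expected to give 35 nM, between 12 nM and 100 nM. The expected step is a 1.5-fold lower number from compound 2 to compound 3 (0.19 log units; within the scatter).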

Compound 3, half-maximal inhibitory concentration: 52 nM
Estimate against measurement, compound 3: 1.5-fold (0.17 log units) below; measured number inside the range.
By their numbers in this assay, from the lowest: compounds 3 and 2 (each within the scatter of the next); then compound 1.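

In this assay, adding ethyl a second time at this place, on a saturated chain carbon, gives a 1.0-fold lower number from compound 2 to compound 3 (0.02 log units; within the scatter) and so does not separate the two compounds, although the first such addition did. Over the whole stretch, butyl in place of hydrogen gives a 3.7-fold lower number from compound 1 to compound 3 (0.56 log units; beyond the scatter) and thus a difference beyond the scatter only against the shortest chain shown, so among these three compounds a longer chain does not always mean a lower number. No other measurement is available to explain this.

Open, from the compounds shown here alone, is whether a longer chain would stay within the scatter of these two compounds or fall apart from them. Also open, going by these compounds, is what a carboxylic acid or an amine at the far end of the chain would do.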